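Series notes: benzyl for thiophen-2-yl at the quaternary carbon

The source may hold more compounds than are shown below. What is called first, only, known or untested is meant among the compounds shown, and "the series" means these compounds.

Three compounds of the shared core have numbers in a functional assay on PC-3 cells (Homo sapiens) for cytotoxicity, read by WST assay, with a stated time of 72 h; on this read-out higher numbers stand for weaker inhibition and lower numbers for stronger inhibition. Compound 1 `Cc1ccc(C2(c3ccc(O)cc3)C(=O)Nc3c2ccc(F)c3F)cc1` gives 0.8 nM. Compound 2 `COc1ccc(C2(c3cccc(O)c3)C(=O)Nc3c2ccc(F)c3F)cc1` differs from compound 1 in several places. Compound 2 gives 145 nM. Compound 3 `O=C1Nc2c(ccc(F)c2F)C1(c1ccc(O)cc1)c1cccs1` gives 0.3 nM, the lowest of the three; the nearest is compound 1 and the furthest compound 2. Within the data shown here, the one single-place step in hand, a 2.7-fold lower number from compound 1 to compound 3 (0.43 log units; beyond the scatter), is modest.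

Compound 4 `O=C1Nc2c(ccc(F)c2F)C1(Cc1ccccc1)c1ccc(O)cc1` is unmeasured. Relative to compound 3: benzyl in place of thiophen-2-yl on a saturated ring carbon. Among the measured compounds shown here, no measured step concerns an aryl-to-benzyl change on this carbon; the only step, from compound 1 to compound 3, shows that exchanging one aromatic group for another there moves the number only modestly. The entering benzyl is of a different kind from any measured variant, so the size of the step is uncertain, and a move toward a higher number is considered more likely than a lower one.

Compound 4 is expected at 5 nM, within 0.5 nM to 50 nM, which corresponds to an expected step of a 17-fold higher number from compound 3 to compound 4 (1.22 log units; beyond the scatter).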

Compound 4, half-maximal inhibitory concentration: > 1000 nM
Compound 4 gave a limit, no number (the forecaster's own chance of this, stated with the estimate: 2%); middle value at least 200-fold (2.30 log units) from the limit.
By their numbers in this assay, from the lowest: compound 3; then compound 1; then compound 2. At a limit, above all of these: compound 4.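

In this assay compound 4 stands at a limit and not at a number: the limit of > 1000 nM in this assay, at which 1 of the 4 values shown sits.

The earlier step at this saturated ring carbon (a 2.7-fold lower number from compound 1 to compound 3 (0.43 log units; beyond the scatter)) was modest and concerned only an exchange of one aromatic group for another directly on the carbon. Benzyl in place of thiophen-2-yl gives a large step (an at least 3300-fold higher number from compound 3 to compound 4 (3.52 log units; beyond the scatter)), and benzyl in place of 4-methylphenyl gives another (an at least 1200-fold higher number from compound 1 to compound 4 (3.09 log units; beyond the scatter)). Among the compounds shown, the position therefore accepts thiophen-2-yl and 4-methylphenyl but not benzyl, and the data give no cause for this.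

Going by these compounds, it remains open whether benzyl alone behaves this way or whether other non-aryl groups on this carbon, such as a 2-phenylethyl chain, an aminomethyl group or a carboxylic acid, do the same. Compound 2 differs in several places and does not bear on this change.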